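The compounds below may be only part of what the source reports. "The series", "measured", "known", "first", "only" and "open" are said of these compounds alone.

Measured so far in an assay on isolated protein for inhibition of Myeloperoxidase (Homo sapiens), read by ELISA, with a stated time of 5 min; a higher number here means a weaker inhibitor, a lower number a stronger inhibitor:
compound 1 `N#CCCCc1c[nH]c2ccc(F)cc12` gives 72 nM
compound 2 `N#CCCCc1c[nH]c2ccc(C(=O)O)cc12` gives "not active" (no number reported)
compound 3 `NC(=O)CCCc1c[nH]c2ccc(F)cc12` gives 18 nM

Compound 2 stands apart from the other two: where compound 1 and compound 3 each give a number, compound 2 gives none and is simply reported as "not active" (no number reported). For the measured compounds named here, the only measured step, a 4.0-fold lower number from compound 1 to compound 3 (0.60 log units; beyond the scatter), concerns a different change and does not bear on the move from compound 2 to compound 4. Compound 4 `NCCCCc1c[nH]c2ccc(C(=O)O)cc12` differs from compound 2 by aminomethyl in place of cyano on a saturated chain carbon, three bonds along the chain from an aromatic carbon. Going by the values given here, with compound 2 showing no activity and no comparable step to go by, compound 4 is expected to stay weak in this assay, and its estimate is 15000 nM, within 2000 nM to 100000 nM, with a real chance that once more only a limit is reported.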

Compound 4, half-maximal inhibitory concentration: "not active" (no number reported)
Compound 4: no number reported, so the estimate cannot be set against anything.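

Compound 2 and compound 4 are both reported as "not active" in this assay, leaving no step to read between them, and no evidence here accounts for this result. Still open, as far as these compounds go, is how the 4-aminobutyl chain would read on the core of compound 1.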